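Trifluoroethyl chain in place of cyclopentyl ring

This account rests on a few compounds, and the source may have more. Where it says the series, first, only, none or still open, it means among the compounds named here.

Measured so far in an assay on CHO cells for displacement of a labelled ligand from C-X-C chemokine receptor type 3 (Homo sapiens), with a stated time of 60 min; a lower number here means a stronger inhibitor, a higher number a weaker inhibitor:
- compound 1, `Cc1cc(CN(CC2CC2)C(CC(=O)O)c2ccc(Cl)cc2)ccc1OCCN1C(=O)CCC1=O`: compound 1 gives 65 nM
- compound 2, `Cc1cc(CN(CC2CCCC2)C(CC(=O)O)c2ccc(Cl)cc2)ccc1OCCN1C(=O)CCC1=O`: compound 2 gives 71 nM
- compound 3, `Cc1cc(CN(CC2CCCC2)[C@@H](CC(=O)O)c2ccc(Cl)cc2)ccc1OCCN1C(=O)CCC1=O`: compound 3 gives 36 nM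

Compound 2 has the highest of the three numbers, but its distances to the other two are both within the scatter: a 1.1-fold higher number from compound 1 to compound 2 (0.04 log units; within the scatter), and a 2.0-fold lower number from compound 2 to compound 3 (0.29 log units; within the scatter), the latter accompanied by the fact that one of compounds 2 and 3 is drawn with a defined configuration and the other without, at the place where they differ.

Compound 4, `Cc1cc(CN(CCC(F)(F)F)C(CC(=O)O)c2ccc(Cl)cc2)ccc1OCCN1C(=O)CCC1=O`, is not yet measured. It differs from compound 2 in one place: 2,2,2-trifluoroethyl in place of cyclopentyl on a saturated chain carbon bound to an amine nitrogen. Among the compounds with values here, the only measured step at this same place is the change from cyclopropyl to cyclopentyl, a 1.1-fold higher number from compound 1 to compound 2 (0.04 log units; within the scatter), which barely moved the number. A three-carbon and a five-carbon ring gave much the same result, so a five-atom fluorinated chain of the same size is expected to leave the number near that of compound 2, with no direction preferred.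

Compound 4 is therefore expected to give about 75 nM in this assay, most likely between 30 nM and 190 nM. That estimate corresponds to a 1.1-fold higher number from compound 2 to compound 4 (0.02 log units; within the scatter), a step not expected to exceed the scatter.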

Compound 4, half-maximal inhibitory concentration: 650 nM
The estimate for compound 4 lay 8.7-fold (0.94 log units) below the measured number; the whole stated range lies below it.
By their numbers in this assay, from the lowest: compounds 3, 1 and 2 (each within the scatter of the next); then compound 4.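

Until now this position looked tolerant, since cyclopropyl and cyclopentyl gave numbers within the scatter of each other. The 2,2,2-trifluoroethyl group changes that picture: both a 9.2-fold higher number from compound 2 to compound 4 (0.96 log units; beyond the scatter) and a 10-fold higher number from compound 1 to compound 4 (1.00 log units; beyond the scatter) lie beyond the scatter, so what sits here does matter, even though the count of heavy atoms stays the same as in cyclopentyl. Nothing available here explains why the number rises so far.

The compounds shown cannot separate the loss of the ring from the arrival of fluorine: a plain propyl chain in place of the 3,3,3-trifluoropropyl, or a cyclopentyl ring carrying fluorine, would tell these two apart. Going by these compounds, compound 4 also has its stereocentre drawn without a configuration, so how its S form would compare remains open.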